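Replacing a fluorinated benzyl group with a pentyl chain

The source may report more compounds than this note shows. Statements on the series, on what has been measured and on what is new or still open speak of the compounds shown alone.

Compound 3 `O=c1c2ccccc2[se]n1-c1nc(SCc2ccc(F)cc2)n[nH]1` is assessed in an ADME assay on L929 cells (Mus musculus) for antiproliferative activity, read by CCK-8 assay, with a stated time of 48 h; a higher number here means a weaker inhibitor, a lower number a stronger inhibitor. In this assay compound 3 gives > 50000 nM, which is a limit of the assay rather than a number. Compound 1 `Cc1ccc(CSc2n[nH]c(-n3[se]c4ccccc4c3=O)n2)cc1` gives in this assay > 50000 nM, again a limit. Compound 2 `Cc1cccc(CSc2n[nH]c(-n3[se]c4ccccc4c3=O)n2)c1` gives in this assay > 50000 nM, also a limit. Because all three sit at the limit of > 50000 nM in this assay, at which 3 of the 3 values shown sit, the steps a step that the two limits leave unreadable from compound 1 to compound 2, a step that the two limits leave unreadable from compound 1 to compound 3 and a step that the two limits leave unreadable from compound 2 to compound 3 cannot be read in size or direction. Compound 4 `CCCCCSc1n[nH]c(-n2[se]c3ccccc3c2=O)n1` carries the change (butyl in place of 4-fluorophenyl on a saturated chain carbon bound to a sulfur). Among the measured compounds shown here, none of the measured steps exchanges an aromatic ring for a chain, so none bears directly on this change; they show only that the three benzyl variants all remain at the limit. The step from compound 3 to compound 4 in this assay is therefore expected to be a step that the limit leaves unreadable from compound 3 to compound 4, with no readable direction. Compound 4 is estimated at 80000 nM, within 30000 nM to 300000 nM, and is most likely to be reported again as a limit.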

Compound 4, half-maximal inhibitory concentration: 33500 nM
The estimate for compound 4 lay 2.4-fold (0.38 log units) above the measured number; measured number inside the range.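

In this assay compound 4 gives 33500 nM, a measured number, which shows that this position, on a saturated chain carbon bound to a sulfur, can carry a group that brings a value inside the range of the assay, something the benzyl variants did not show: the limit of > 50000 nM in this assay, at which 3 of the 4 values shown sit.

The exchange for the chain gives an at least 1.4-fold lower number from compound 3 to compound 4 (0.17 log units; that floor lies within the scatter), an at least 1.4-fold lower number from compound 2 to compound 4 (0.17 log units; that floor lies within the scatter) and an at least 1.4-fold lower number from compound 1 to compound 4 (0.17 log units; that floor lies within the scatter). Each of these is only a floor within the scatter, so the change is not shown to exceed the scatter, while the steps among compound 1, compound 2 and compound 3 remain unreadable.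

The compounds shown leave open how a propyl or octyl chain would read here. They also leave open what a pentyl chain carrying an amine or a carboxylic acid would give.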